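Swapping the ring for an open chain on the aromatic amine

The source may report more compounds than this note shows. Statements on the series, on what has been measured and on what is new or still open speak of the compounds shown alone.

Among the measured compounds shown here, compound 2 `N=S1(=O)CC(Nc2nonc2/C(=N/O)Nc2ccc(F)c(Br)c2)C1` is one of two compounds measured in an assay on isolated protein for inhibition of Indoleamine 2,3-dioxygenase 1 (Homo sapiens), read by fluorescence, with a stated time of 60 min (a higher number here means a weaker inhibitor, a lower number a stronger inhibitor), where compound 2 gives 208 nM. Compound 1 `NS(=O)(=O)NNc1nonc1/C(=N/O)Nc1ccc(F)c(Br)c1` gives 218 nM in this assay. Compound 2 has the lower of the two numbers, but the difference is within the scatter: a 1.0-fold lower number from compound 1 to compound 2 (0.02 log units; within the scatter), a change that replaced an open-chain group on the nitrogen on the aromatic ring with a ring-bearing group. The new compound 3 `NS(=O)(=O)CCNc1nonc1/C(=N/O)Nc1ccc(F)c(Br)c1` reverses that kind of move on the same nitrogen: a group of 6 heavy atoms (2 carbon, 1 nitrogen, 2 oxygen, 1 sulfur; no ring) in place of a group of 6 heavy atoms (3 carbon, 1 nitrogen, 1 oxygen, 1 sulfur; one four-membered non-aromatic ring with 1 hetero atom), on a nitrogen on an aromatic ring. For the measured compounds named here, the one measured step that bears on this, the swap of an open chain for the ring between compound 1 and compound 2, left the number unchanged, so the step back to an open chain is expected to stay within the scatter as well, a 1.1-fold higher number from compound 2 to compound 3 (0.02 log units; within the scatter). Compound 3 is therefore estimated to give 220 nM, within the range 100 nM to 480 nM.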

Compound 3, half-maximal inhibitory concentration: 71 nM
Estimate against measurement, compound 3: 3.1-fold (0.49 log units) above; measured number outside the range, below it.
By their numbers in this assay, from the lowest: compound 3; then compounds 2 and 1 (each within the scatter of the next).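

The group on the nitrogen on the aromatic ring can shift the number in this assay, which the first two compounds did not show: 2-sulfamoylethyl gives a 2.9-fold lower number from compound 2 to compound 3 (0.47 log units; beyond the scatter) and a 3.1-fold lower number from compound 1 to compound 3 (0.49 log units; beyond the scatter). An open chain alone does not bring this gain, since compound 1 also carries one and stays within the scatter of compound 2, and the groups exchanged between compound 2 and compound 3 have equal counts of heavy atoms, hydrogen-bond donors and hydrogen-bond acceptors. No measurement is at hand to explain the change.

As far as these compounds go, it remains open how the number responds to the length of the chain, as with a propyl chain bearing the same sulfamoyl end. From the compounds shown here alone, it is equally open whether a carboxylic acid or an amine at the end of the ethyl chain would give a similar number.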